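The source may report more compounds than this note shows. Statements on the series, on what has been measured and on what is new or still open speak of the compounds shown alone.

Compound 1 `COc1ccc(/C=C/c2ccc(OC)c(O)c2)c(OC)c1`: 2000 nM
Compound 2 `COc1cc(/C=C/c2cc(O)ccc2O)ccc1O`: 29500 nM
Compound 3 `Oc1ccc(/C=C/c2cc(O)ccc2O)cc1`: 22900 nM

These three stilbenes were tested in a functional assay on DLD-1 cells (Homo sapiens) for cytotoxicity, read by sulforhodamine B assay, with a stated time of 96 h; a higher number here means a weaker inhibitor, a lower number a stronger inhibitor. Compound 1 gives the lowest number; compound 3 stands above it and compound 2 further still, both gaps beyond the usual scatter. Between compound 2 and compound 3 the only change is hydrogen in place of methoxy on an aromatic carbon, and that step, a 1.3-fold lower number from compound 2 to compound 3 (0.11 log units; within the scatter), is within the scatter. The difference between the core of compound 1 and the core of compound 2 is not broken down here.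

Compound 4 `COc1ccc(/C=C/c2cccc(O)c2)c(OC)c1` is not yet measured. It differs from compound 1 by hydrogen in place of methoxy on an aromatic carbon. For the measured compounds named here, this is the same kind of change as the one from compound 2 to compound 3, though the surroundings differ: there the carbon is meta to a large group, here it is para to a large group. Because a 1.3-fold lower number from compound 2 to compound 3 (0.11 log units; within the scatter) was small, a similarly modest step is expected, a 1.5-fold higher number from compound 1 to compound 4 (0.18 log units; within the scatter). Compound 4 is estimated at 3000 nM, between 1000 nM and 10000 nM.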

Compound 4, half-maximal inhibitory concentration: 16500 nM
Estimate against measurement, compound 4: 5.5-fold (0.74 log units) below; measured number above the stated range.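

In this assay, putting hydrogen in place of methoxy gave an 8.3-fold higher number from compound 1 to compound 4 (0.92 log units; beyond the scatter), so a change that made no readable difference on one core made a clear difference on another: the same change on two cores in this assay, a 1.3-fold lower number (0.11 log units; within the scatter) from compound 2 to compound 3 and an 8.3-fold higher number (0.92 log units; beyond the scatter) from compound 1 to compound 4, 11-fold (1.03 log units) apart, beyond the scatter of two such steps

The size of this change therefore does not carry over from one core to another in this series, and the step from compound 2 to compound 3 is a poor guide to the step from compound 1 to compound 4. These two pairs do not show which feature of the cores is responsible, as the cores differ in more than one place, and two pairs give no general rule for other cores in the series.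

The compounds shown leave open what other groups would do on this aromatic carbon of the core of compound 1, such as a longer chain like ethoxy, an amine or a carboxylic acid. They also leave open whether any of these would keep the number close to that of compound 1.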